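A few compounds are considered here, and "the series" means these few. Any claim that something is new, unique, unknown or untested is made for them only; others in the source may bear on it.

Measured so far in the series:
Compound 1 `O=c1nc(NCC2CCCCC2)oc2c([N+](=O)[O-])cc(C(F)(F)F)cc12` gives 29.7 ug/mL in an ADME assay on Vero cells (Chlorocebus sabaeus) for cytotoxicity, read by MTT assay, with a stated time of 48 h; on this read-out lower numbers stand for stronger inhibition and higher numbers for weaker inhibition.
Compound 2 `CN(Cc1ccccc1)c1nc(=O)c2cc(C(F)(F)F)cc([N+](=O)[O-])c2o1` gives 3.84 ug/mL in this assay.
Compound 3 `O=c1cc(NCC2CCCCC2)sc2c([N+](=O)[O-])cc(C(F)(F)F)cc12` shows only a limit of the assay in this assay, namely > 64 ug/mL.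

Among the compounds with values here, the one counted step is benzyl(methyl)amino in place of (cyclohexylmethyl)amino on an aromatic carbon, which gives a 7.7-fold lower number from compound 1 to compound 2 (0.89 log units; beyond the scatter). Within the data shown here, the difference between the core of compound 1 and the core of compound 3 is not broken down here; the value of compound 3 is the limit of > 64 ug/mL in this assay, at which 1 of the 3 values shown sits, so no step to it can be sized.

Compound 4 `CN(Cc1ccccc1)c1cc(=O)c2cc(C(F)(F)F)cc([N+](=O)[O-])c2s1` is not yet measured. It differs from compound 3 by benzyl(methyl)amino in place of (cyclohexylmethyl)amino on an aromatic carbon. This is the same kind of change as that from compound 1 to compound 2, but the surroundings differ: in compound 1 the carbon lies in a ring with 1 nitrogen and 1 oxygen, next to the ring nitrogen and next to the ring oxygen, whereas in compound 3 it lies in a ring with 1 sulfur, next to the ring sulfur.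

On these data alone, for compound 4 in this assay the expected step is an at least 3.2-fold lower number from compound 3 to compound 4 (0.50 log units; beyond the scatter), resting on the earlier step of a 7.7-fold lower number from compound 1 to compound 2 (0.89 log units; beyond the scatter) and on the fact that compound 3 gave only a limit, so the starting number is unknown. The estimate for compound 4 is 20 ug/mL, with a range from 7 ug/mL to 64 ug/mL; a limit again is a real possibility.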

Compound 4, half-maximal inhibitory concentration: > 64 ug/mL
Compound 4: no number, only a limit (the forecaster's own chance of this, stated with the estimate: 35%); middle value at least 3.2-fold (0.50 log units) from the limit.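

In this assay compound 4 gives > 64 ug/mL, which is a limit of the assay and not a number. Within the data shown here, no step from compound 3 to compound 4 can be read, because both compounds stand at the same limit: the limit of > 64 ug/mL in this assay, at which 2 of the 4 values shown sit. The compounds shown leave open whether benzyl(methyl)amino in place of (cyclohexylmethyl)amino changes the number on the core of compound 3 as it does on the core of compound 1.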